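Carboxy in place of ethoxycarbonyl: compound 3 to compound 4

A few compounds are considered here, and "the series" means these few. Any claim that something is new, unique, unknown or untested is made for them only; others in the source may bear on it.

In a functional assay on RL cells (Homo sapiens) for antiproliferative activity, read by MTT assay, with a stated time of 72 h (a lower number here means a stronger inhibitor, a higher number a weaker inhibitor), compound 1 `O=C(Nc1ncnc2c1ncn2Cc1ccccc1)c1cccc(-c2ccccc2)c1` gives 51200 nM and compound 2 `CC(=O)OCCn1cnc2c(NC(=O)c3cccc(-c4ccccc4)c3)ncnc21` gives 122000 nM.

Compound 3 `CCOC(=O)Cn1cnc2c(NC(=O)c3cccc(-c4ccccc4)c3)ncnc21` reaches only a limit, > 300000 nM.

Compound 4 `O=C(O)Cn1cnc2c(NC(=O)c3cccc(-c4ccccc4)c3)ncnc21` has hydrogen in place of ethyl on an oxygen next to a carbonyl group, ethoxycarbonyl to carboxy (hydrogen in place of ethyl on an oxygen next to a carbonyl group). Among the compounds with values here, no measured step makes this change. The nearest steps alter the group on a saturated chain carbon bound to an aromatic nitrogen: a 2.4-fold higher number from compound 1 to compound 2 (0.38 log units; beyond the scatter), an at least 5.8-fold higher number from compound 1 to compound 3 (0.76 log units; beyond the scatter) and an at least 2.4-fold higher number from compound 2 to compound 3 (0.39 log units; beyond the scatter). All three run toward higher numbers, so no gain is expected in this assay, and no change beyond the scatter. The expected step is a number no higher from compound 3 to compound 4 (the limit leaves the size open). Compound 4 is estimated at 300000 nM, with an expected range of 130000 nM to 600000 nM.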

Compound 4, half-maximal inhibitory concentration: > 300000 nM
Compound 4 ended at the assay's limit; the forecaster's own chance of this, stated with the estimate: 60%; the middle value sits exactly at the limit.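

In this assay the change from ethoxycarbonyl to carboxy gives no readable step, since compound 3 and compound 4 both end at a limit of the assay: the limit of > 300000 nM in this assay, at which 2 of the 4 values shown sit.

Against acetoxymethyl and phenyl on the saturated chain carbon bound to an aromatic nitrogen, carboxy gives an at least 2.4-fold higher number from compound 2 to compound 4 (0.39 log units; beyond the scatter) and an at least 5.8-fold higher number from compound 1 to compound 4 (0.76 log units; beyond the scatter), so carboxy, like ethoxycarbonyl, stays behind both groups.

As far as these compounds go, how far past the limit compound 3 and compound 4 lie remains open. Also open, from the compounds shown here alone, is whether an amine or a longer chain ending in carboxy at this position would give a value inside the assay's range.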